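Swapping a cyclohexyl for a hex-1-yn-1-yl chain

This account rests on a few compounds, and the source may have more. Where it says the series, first, only, none or still open, it means among the compounds named here.

Measured compounds:
compound 1, `Cc1[nH]c2ccccc2c(=O)c1C1CCCCC1`: 260 10^-6 cm/s
compound 2, `Cc1[nH]c2ccc(Br)cc2c(=O)c1Br`: 133 10^-6 cm/s

In an ADME assay for permeability, using PAMPA, at pH 4 (a lower number here means that the compound crosses the layer more slowly, a higher number that the compound crosses the layer faster), compound 1 gives 260 10^-6 cm/s, and compound 2 gives 133 10^-6 cm/s. These two numbers lie within the usual scatter of each other, so neither compound stands apart on this assay. Compound 3, `CCCCC#Cc1c(C)[nH]c2ccccc2c1=O`, has not yet been measured. It differs from compound 1 in one place: hex-1-yn-1-yl in place of cyclohexyl on an aromatic carbon. Among the compounds with values here, no measured pair shows a step of this kind, so the expected step from compound 1 to compound 3 is a 1.2-fold lower number from compound 1 to compound 3 (0.07 log units; within the scatter), with no change beyond the scatter. Compound 3 is thus estimated at 220 10^-6 cm/s, within 110 10^-6 cm/s to 400 10^-6 cm/s.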

Compound 3, apparent permeability: 500 10^-6 cm/s
Estimate against measurement, compound 3: 2.3-fold (0.36 log units) below; the measured number lies above the stated range.
By their numbers in this assay, from the lowest: compounds 2, 1 and 3 (each within the scatter of the next, the first and the last beyond it).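

At this position, on an aromatic carbon of the shared core, the first measured step replaces the ring of cyclohexyl with the open hex-1-yn-1-yl chain, which has the same heavy-atom count and a triple bond. In this assay, this gives a 1.9-fold higher number from compound 1 to compound 3 (0.28 log units; within the scatter), so the ring can give way to this chain without a change beyond the scatter. No measurement shown here offers an explanation for this step. Open, on these data alone, is whether a hexyl chain without the triple bond, or a chain ending in an amine or a carboxylic acid, would move the number beyond the scatter.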